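The compounds below may be only part of what the source reports. "The series", "measured", "known", "first", "only" and "open" are said of these compounds alone.

The measured compounds in a functional assay on UO-31 cells (Homo sapiens) for inhibition, read by sulforhodamine B assay, with a stated time of 48 h, tested at 10 uM; on this read-out lower numbers stand for less inhibition and higher numbers for more inhibition at the one concentration tested (going by the name of the read-out):
compound 1 `Brc1cn2ccnc2c(-c2ccc3ncn(C4CCCCC4)c3c2)n1` gives 37.6%
compound 2 `O=Cc1ccc(-c2cn3ccnc3c(-c3ccc4ncn(C5CCCCC5)c4c3)n2)cc1` gives 82.2%
compound 3 `Clc1ccc(-c2cn3ccnc3c(-c3ccc4ncn(C5CCCCC5)c4c3)n2)cc1` gives 36.1%

Among these three, compound 3 has the lowest number, though its distance to compound 1, a number 1.5 percentage points lower from compound 1 to compound 3 (within the scatter), is within the scatter; only compound 2 stands clearly apart, as a number 46.1 percentage points lower from compound 2 to compound 3 (beyond the scatter) shows. Compound 4 `Brc1ccc(-c2cn3ccnc3c(-c3ccc4ncn(C5CCCCC5)c4c3)n2)cc1` differs from compound 3 by a single substitution: bromo in place of chloro on an aromatic carbon. Going by the values given here, no measured step swaps one halogen for another at this place, so the expectation rests on indirect evidence. The step of a number 44.6 percentage points higher from compound 1 to compound 2 (beyond the scatter) and the step of a number 46.1 percentage points lower from compound 2 to compound 3 (beyond the scatter) show that the group on this ring can move the read-out strongly, but both steps involve a formyl group; the step of a number 1.5 percentage points lower from compound 1 to compound 3 (within the scatter) shows a chlorophenyl behaving much like a bare bromo on the core. With one halogen giving way to another, neither bringing donors or acceptors, a step within the scatter is expected for compound 4 in this assay, namely a number 1.9 percentage points higher from compound 3 to compound 4 (within the scatter). Compound 4 is therefore estimated at 38%, with a range from 26% to 52%.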

Compound 4, a percentage reported as inhibition, at one concentration (the size of the read-out at that concentration, not a potency): 42.9%
For compound 4 the middle estimate is 4.9 percentage points below the measured one; low and high end bracket the measured number.
By their numbers in this assay, from the lowest: compounds 3, 1 and 4 (each within the scatter of the next); then compound 2.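

In this assay, going by these compounds alone, this is the first direct exchange of one halogen for another at this place, on the six-membered aromatic ring and para to a large group, and bromo in place of chloro gives a number 6.8 percentage points higher from compound 3 to compound 4 (within the scatter), so the two halogens cannot be told apart here. The result also sets the formyl compound further apart, with a number 39.3 percentage points lower from compound 2 to compound 4 (beyond the scatter), while adding the ring to the core gives a number 5.3 percentage points higher from compound 1 to compound 4 (within the scatter); among the compounds shown, the 4-bromophenyl group alone therefore does not bring the high number seen with compound 2. Nothing available here explains why compound 2 stands so far from the two halogen compounds.

From the compounds shown here alone, it remains open whether the high number depends on the formyl group itself, or whether a carboxylic acid, a hydroxymethyl group or an aminomethyl group at this place would give a similar number. A single concentration in one cell line also leaves open how these compounds would compare across a range of concentrations or in other cell lines.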